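A few compounds are considered here, and "the series" means these few. Any claim that something is new, unique, unknown or untested is made for them only; others in the source may bear on it.

Compound 3 `O=C(/C=C/c1ccc(OCc2nc(C3CCN(Cc4ccccc4F)CC3)no2)cc1)NO` is one of three compounds sharing a core and measured in an assay on isolated protein for inhibition of protein deacetylase HDAC6 (Homo sapiens), read by fluorescence, with a stated time of 1 h, tested at 100 nM (on this read-out higher numbers stand for more inhibition at the one concentration tested (going by the name of the read-out) and lower numbers for less inhibition), where compound 3 gives 68%. Its companions differ from it only in the group on a saturated chain carbon bound to an amine nitrogen in a ring: compound 1 `CCCN1CCC(c2noc(COc3ccc(/C=C/C(=O)NO)cc3)n2)CC1` gives 69% in this assay, and compound 2 `Cc1ccc(CN2CCC(c3noc(COc4ccc(/C=C/C(=O)NO)cc4)n3)CC2)cc1` gives 76%. On these numbers compound 3 sits at the low end of the three, but the gap a number 1 percentage points lower from compound 1 to compound 3 (within the scatter) lies within the scatter, as does a number 8 percentage points lower from compound 2 to compound 3 (within the scatter), and the remaining pair, a number 7 percentage points higher from compound 1 to compound 2 (within the scatter), also stays within the scatter. The three measured steps together show that swapping ethyl, 4-methylphenyl and 2-fluorophenyl at this position has not moved the read-out beyond the noise.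

Compound 4 `O=C(/C=C/c1ccc(OCc2nc(C3CCN(Cc4ccc(F)c(F)c4)CC3)no2)cc1)NO` arises from compound 3 by the change (3,4-difluorophenyl in place of 2-fluorophenyl on a saturated chain carbon bound to an amine nitrogen in a ring). Every measured step at this same position bears on it, and every one of them was within the scatter, so a step within the scatter is expected in this assay, with no preferred direction. The expected step of a number 1 percentage points higher from compound 3 to compound 4 (within the scatter) is therefore essentially flat. Compound 4 is estimated to give 69% in this assay, with a range from 56% to 82%.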

Compound 4, a percentage reported as inhibition, at one concentration (the size of the read-out at that concentration, not a potency): 60%
Compound 4: middle estimate off by 9 percentage points, on the high side; measured number inside the range.
By their numbers in this assay, from the lowest: compounds 4, 3, 1 and 2 (each within the scatter of the next, the first and the last beyond it).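

For the compounds shown here, the position is not entirely flat: a number 16 percentage points lower from compound 2 to compound 4 (beyond the scatter) in this assay is the first step here to pass beyond the scatter, which shows that the group on a saturated chain carbon bound to an amine nitrogen in a ring can shift this read-out, if only modestly. The separation is confined to one pair, since both a number 8 percentage points lower from compound 3 to compound 4 (within the scatter) and a number 9 percentage points lower from compound 1 to compound 4 (within the scatter) remain within the scatter, so 3,4-difluorophenyl stands apart from 4-methylphenyl but not from 2-fluorophenyl or ethyl. Nothing available explains the gap between 4-methylphenyl and 3,4-difluorophenyl.

The compounds shown leave open whether a plain phenyl would fall with 4-methylphenyl or with 3,4-difluorophenyl, which would help to tell whether the methyl group or the two fluorine atoms matter more to this step. They also leave open whether a carboxylic acid, a hydroxyl group or a longer chain at this position would move the read-out further than the groups seen so far, and in which direction.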